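Series notes: amide aryl swap on the shared core

The source may report more compounds than this note shows. Statements on the series, on what has been measured and on what is new or still open speak of the compounds shown alone.

Measured so far:
compound 1 `O=C(Nc1cc(-c2ccccc2)nn1-c1ccccc1)c1ccc(F)cc1`: 30 nM
compound 2 `O=C(Nc1cc(-c2ccccc2)nn1-c1ccccc1)c1ccccc1O`: > 10000 nM

In an assay on CHO cells with metabotropic glutamate receptor 5 (Homo sapiens) as the target (on this read-out lower numbers stand for an effect already at smaller amounts and higher numbers for an effect only at larger amounts of compound), compound 1 gives 30 nM. For compound 2 the value > 10000 nM is a limit of the assay, not a number (the limit of > 10000 nM in this assay, at which 1 of the 2 values shown sits). Going by the values given here, the one measured step, an at least 330-fold higher number from compound 1 to compound 2 (2.52 log units; beyond the scatter), was large. Compound 3 `Cc1cccc(C(=O)Nc2cc(-c3ccccc3)nn2-c2ccccc2)c1` carries the change (3-methylphenyl in place of 2-hydroxyphenyl on a carbonyl carbon). Among the compounds with values here, no measured step matches this change; the only evidence is that compound 1 gives 30 nM. For compound 2, with its 2-hydroxyphenyl, the value > 10000 nM is a limit of the assay. A large step downward in this assay is therefore expected: an at least 100-fold lower number from compound 2 to compound 3 (2.00 log units; beyond the scatter). For compound 3 the estimate in this assay is 100 nM, between 15 nM and 1000 nM.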

Compound 3, half-maximal effective concentration: 90 nM
Beside the measured number, compound 3's estimate is 1.1-fold (0.05 log units) above it; the measured number falls inside the stated range.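

On the carbonyl carbon, 3-methylphenyl brings back a measurable number where 2-hydroxyphenyl gave none: an at least 110-fold lower number from compound 2 to compound 3 (2.04 log units; beyond the scatter). The value for compound 2 is a limit of the assay, not a number: the limit of > 10000 nM in this assay, at which 1 of the 3 values shown sits. Going from 4-fluorophenyl to 3-methylphenyl changes far less, a 3.0-fold higher number from compound 1 to compound 3 (0.48 log units; beyond the scatter), so two differently substituted phenyl groups hold activity here, with compound 2 the one case against this.

The compounds shown do not separate the hydroxyl from its ring position, and 2-methylphenyl or 3-hydroxyphenyl would address that. On these data alone, how an amine or a carboxylic acid on this phenyl would read also remains open.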